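A few compounds are considered here, and "the series" means these few. Any claim that something is new, unique, unknown or untested is made for them only; others in the source may bear on it.

Compound 3 `Cc1ccc(-c2cccc(Oc3ccc4c(c3)c(=O)ncn4Cc3c(F)cc(F)cc3F)c2C(F)(F)F)cn1` stands at a limit in a physicochemical assay for solubility, using the shake flask method, with a stated time of 24 h, at pH 6.8; a lower number here means a less soluble compound, a higher number a more soluble compound: its solubility is reported as < 0.1 ug/mL, a limit rather than a number. Compound 1 `O=c1ncn(Cc2c(F)cc(F)cc2F)c2ccc(Oc3cccc(-c4ccc5cc[nH]c5c4)c3C(F)(F)F)cc12` also returns only a limit, < 0.1 ug/mL. Compound 2 `Nc1ccc(-c2cccc(Oc3ccc4c(c3)c(=O)ncn4Cc3c(F)cc(F)cc3F)c2C(F)(F)F)cn1` likewise gives only a limit, < 0.1 ug/mL. The steps a step that the two limits leave unreadable from compound 1 to compound 2, a step that the two limits leave unreadable from compound 1 to compound 3 and a step that the two limits leave unreadable from compound 2 to compound 3 are all of unreadable size, since (the limit of < 0.1 ug/mL in this assay, at which 3 of the 3 values shown sit). Compound 4 `Cc1cc(-c2cccc(Oc3ccc4c(c3)c(=O)ncn4Cc3c(F)cc(F)cc3F)c2C(F)(F)F)cnc1N` differs from compound 3 by 6-amino-5-methylpyridin-3-yl in place of 6-methylpyridin-3-yl on an aromatic carbon. Within the data shown here, none of the measured steps gives a readable size for a change of this kind, so no direction in this assay can be drawn from them. Compound 4 is expected to remain at the limit, with an estimated 0.05 ug/mL, between 0.01 ug/mL and 0.2 ug/mL. The expected step that the limit leaves unreadable from compound 3 to compound 4 is thus no change beyond the scatter.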

Compound 4, solubility: < 0.1 ug/mL
Compound 4 gave a limit, no number; the forecaster's own chance of this, stated with the estimate: 80%; the middle value lies beyond the limit too.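

Among these compounds, no step from compound 1, compound 2 or compound 3 to compound 4 can be read in this assay, as all four values are limits: the limit of < 0.1 ug/mL in this assay, at which 4 of the 4 values shown sit. The compounds shown leave open whether these groups differ at all in solubility.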